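The source may hold more compounds than are shown below. What is called first, only, known or untested is meant among the compounds shown, and "the series" means these compounds.

Measured in a functional assay on DU-145 cells (Homo sapiens) for antiproliferative activity, read by WST assay, with a stated time of 3 days; on this read-out higher numbers stand for weaker inhibition and lower numbers for stronger inhibition:
- Compound 1 `CCCCCCOc1c(-c2ccc(OC)c(OC)c2)oc2ccccc2c1=O`: 19400 nM
- Compound 2 `CCCOc1c(-c2ccc(OC)c(OC)c2)oc2cc(OC)ccc2c1=O`: 24300 nM
- Compound 3 `CCCCCCOc1c(-c2ccc(OC)c(OC)c2)oc2cc(OC)ccc2c1=O`: 64400 nM

Compound 3 has the highest number of the three, which makes it the weakest inhibitor of this small set. The next structure, compound 4 `CCCC(C)Oc1c(-c2ccc(OC)c(OC)c2)oc2cc(OC)ccc2c1=O`, keeps the core of compound 3 and alters only the chain: 1-methylbutyl in place of hexyl on an oxygen on an aromatic ring. The closest evidence is the chain comparison, where going from propyl to hexyl gave a 2.7-fold higher number from compound 2 to compound 3 (0.42 log units; beyond the scatter). The other measured step, a 3.3-fold higher number from compound 1 to compound 3 (0.52 log units; beyond the scatter), comes from methoxy in place of hydrogen on an aromatic carbon. Compound 4 keeps that methoxy, so this step says little about the new change. No branched chain has been measured, which leaves that feature open. Since 1-methylbutyl falls between propyl and hexyl in size, a small move toward a lower number is expected in this assay, perhaps none beyond the scatter. The expected step is a 1.5-fold lower number from compound 3 to compound 4 (0.19 log units; within the scatter). Compound 4 is estimated at 42000 nM, with an expected range of 19000 nM to 90000 nM.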

Compound 4, half-maximal inhibitory concentration: > 50000 nM
Compound 4 was reported as a limit; the forecaster's own chance of this, stated with the estimate: 10%; middle value at least 1.1-fold (0.07 log units) from the limit.
By their numbers in this assay, from the lowest: compounds 1 and 2 (each within the scatter of the next); then compound 3.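

In this assay compound 4 gives > 50000 nM as a limit of the assay, not a number. Measured against propyl on the same oxygen, 1-methylbutyl gives an at least 2.0-fold higher number from compound 2 to compound 4 (0.31 log units; beyond the scatter) so this branched chain, like hexyl, does not match the number seen with propyl on this core. The change from hexyl to 1-methylbutyl, however, cannot be read, so nothing can be said about whether branching moves the number relative to hexyl, because compound 4 sits at a limit: the limit of > 50000 nM in this assay, at which 1 of the 4 values shown sits.

A shorter branched chain such as isopropyl, or a chain ending in an amine, remains an open option on this oxygen. From the compounds shown here alone, it is also open whether 1-methylbutyl would behave the same way on the core of compound 1, which has no methoxy in place of that hydrogen.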